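Notes on the shared core: methyl in place of fluoro

The compounds below may be only part of what the source reports. "The series", "measured", "known", "first", "only" and "open" are said of these compounds alone.

a functional assay on CHO-K1 cells with Glucose-dependent insulinotropic receptor (Homo sapiens) as the target, read by a luciferase reporter, with a stated time of 5 h (a higher number here means a larger maximal response, a lower number a smaller maximal response), is the read-out followed here. Among the measured compounds shown here, compound 1 `CC(C)OC(=O)N1CCC(Oc2ncnc3c2CCN3c2ccc(S(C)(=O)=O)cc2F)CC1` gives 91% in this assay, the higher of the two numbers measured so far. Compound 2 `COCCOC(=O)N1CCC(Oc2ncnc3c2CCN3c2ccc(S(C)(=O)=O)cc2F)CC1` gives 86% in this assay; the step of a number 5 percentage points lower from compound 1 to compound 2 (within the scatter) stays within the scatter, so the two compounds cannot be ordered on these data.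

Compound 3 `Cc1cc(S(C)(=O)=O)ccc1N1CCc2c(OC3CCN(C(=O)OC(C)C)CC3)ncnc21` has not yet been measured in this assay. It differs from compound 1 as follows: methyl in place of fluoro on an aromatic carbon The change sits on an aromatic carbon of a six-membered aromatic ring of carbon only, ortho to a large group and meta to a methylsulfonyl group. For the measured compounds named here, no measured step touches this ring; the only step measured, a number 5 percentage points lower from compound 1 to compound 2 (within the scatter), alters a different part of the molecule and remains within the scatter. Nothing in the data points to a larger or smaller maximal response, so for compound 3 a step no larger than the scatter is expected: a number 3 percentage points lower from compound 1 to compound 3 (within the scatter). In this assay compound 3 is estimated at 88%, with a range of 74% to 100%.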

Compound 3, largest response reached (reported as percent of maximum), in percent of the reference or control that the assay uses: 80%
Compound 3: the middle estimate sits 8 percentage points above what was measured; low and high end bracket the measured number.
By their numbers in this assay, from the lowest: compounds 3, 2 and 1 (each within the scatter of the next, the first and the last beyond it).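

Methyl in place of fluoro on this aromatic carbon, ortho to a large group and meta to a methylsulfonyl group, gives a number 11 percentage points lower from compound 1 to compound 3 (beyond the scatter) in this assay and is the only change shown so far whose step lies beyond the scatter. The maximal response is therefore sensitive to this one position on the 2-fluoro-4-(methylsulfonyl)phenyl group, which the change from isopropyl to 2-methoxyethyl could not show, yet the step is modest and compound 3 keeps a clear response at 80% in this assay. No supporting measurement bears on this result, so the data offer no explanation for the step.

The compounds shown leave open whether the lower response follows from the loss of fluoro or from the arrival of methyl, a question that hydrogen, chloro, methoxy or nitrile on the same aromatic carbon could help separate. They also leave open whether the same step would appear with 2-methoxyethyl in place of isopropyl, and a single pair cannot establish a trend at this position.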